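Swapping methyl for bromo on the fused ring of compound 2

The source may report more compounds than this note shows. Statements on the series, on what has been measured and on what is new or still open speak of the compounds shown alone.

Three compounds share one core and differ only at two points. Compound 1 `Cc1[nH]n(-c2nc3cc(-c4ccccc4)ccc3[nH]2)c(=O)c1Cc1ccccc1` carries a phenyl on the fused ring and gives 810 nM in an assay on isolated protein for inhibition of alpha-ketoglutarate-dependent dioxygenase alkB homolog 3 (Homo sapiens), read by polymerase chain reaction, with a stated time of 1 h; a higher number here means a weaker inhibitor, a lower number a stronger inhibitor. Compound 2 `Cc1ccc2[nH]c(-n3[nH]c(C)c(Cc4ccccc4)c3=O)nc2c1` carries a methyl at that same position instead, and in this assay compound 2 gives 670 nM; the step of a 1.2-fold lower number from compound 1 to compound 2 (0.08 log units; within the scatter) says these two numbers cannot be told apart. Compound 3 `Cc1ccc2[nH]c(-n3[nH]c(C)c(Cc4ccc(-c5ccccc5)cc4)c3=O)nc2c1` adds a phenyl to the pendant benzyl group, and in this assay compound 3 gives 5300 nM, a clear weakening described by a 7.9-fold higher number from compound 2 to compound 3 (0.90 log units; beyond the scatter). Compound 2 thus holds the smallest of the three numbers, but only compound 3 sits beyond the scatter from it.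

The new compound 4 `Cc1[nH]n(-c2nc3cc(Br)ccc3[nH]2)c(=O)c1Cc1ccccc1` again changes the fused-ring substituent: bromo in place of methyl on an aromatic carbon. Going by the values given here, the only measured step that bears on this position is a 1.2-fold lower number from compound 1 to compound 2 (0.08 log units; within the scatter), where exchanging a bulky phenyl for a small methyl moved the number hardly at all. A one-atom bromo replacing a one-atom methyl is a smaller change still, so no step beyond the scatter is expected in this assay, in either direction. Compound 4 is therefore expected to give about 700 nM, within 300 nM to 1600 nM, which corresponds to an estimated step of a 1.0-fold higher number from compound 2 to compound 4 (0.02 log units; within the scatter).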

Compound 4, half-maximal inhibitory concentration: 490 nM
Compound 4: the middle estimate sits 1.4-fold (0.15 log units) above what was measured; the range from low to high includes it.
By their numbers in this assay, from the lowest: compounds 4, 2 and 1 (each within the scatter of the next); then compound 3.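

Until now this position on the fused ring had carried only carbon groups, phenyl and methyl; bromo puts a different element there, and in this assay replacing methyl with it gives a 1.4-fold lower number from compound 2 to compound 4 (0.14 log units; within the scatter) and no change that can be read. Replacing phenyl with bromo gives a 1.7-fold lower number from compound 1 to compound 4 (0.22 log units; within the scatter), so compounds 1, 2 and 4 cannot be told apart, and the three groups tried at this position leave the number within the scatter, whereas the phenyl added to the pendant benzyl group in compound 3 gives a 7.9-fold higher number from compound 2 to compound 3 (0.90 log units; beyond the scatter) at a different place on the molecule. Nothing measured here explains why these three groups give such similar numbers.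

The compounds shown leave open whether this tolerance extends to groups of a different kind at the same position, such as an amine, a carboxylic acid or a longer chain, any of which could reveal a limit that phenyl, methyl and bromo do not. They also leave open what a plain hydrogen at this position would give, which would show whether having any substituent there matters at all.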